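Adding a Methoxy Group to a Weak Growth Inhibitor

A few compounds are considered here, and "the series" means these few. Any claim that something is new, unique, unknown or untested is made for them only; others in the source may bear on it.

Compound 1 `C=C(C)[C@@H]1CC=C(Cn2cc(COc3ccc(C4NC(=O)NC(C)=C4C(=O)OCC)cc3)nn2)CC1` gives 92200 nM in a functional assay on PC-3 cells (Homo sapiens) for inhibition, read by sulforhodamine B assay, with a stated time of 48 h; on this read-out higher numbers stand for weaker inhibition of growth and lower numbers for stronger inhibition of growth.
Compound 2 `C=C(C)[C@@H]1CC=C(Cn2cc(COc3cc(C4NC(=O)NC(C)=C4C(=O)OCC)ccc3OC)nn2)CC1` gives > 100000 nM in this assay; this is a limit of the assay, not a number.

Within the data shown here, compound 1 thus stands as the only compound with a number; the other result sits at the limit of > 100000 nM in this assay, at which 1 of the 2 values shown sits. Compound 3 `C=C(C)[C@@H]1CC=C(Cn2cc(COc3ccc(C4NC(=O)NC(C)=C4C(=O)OCC)cc3OC)nn2)CC1` differs from compound 1 by methoxy in place of hydrogen on an aromatic carbon. Among the measured compounds shown here, no step between measured compounds exists to lean on. The step from compound 1 to compound 3 is expected to be a 1.3-fold higher number from compound 1 to compound 3 (0.11 log units; within the scatter), small and towards weaker inhibition or none beyond the scatter. Compound 3 is estimated at 120000 nM, in the range 50000 nM to 300000 nM, with a fair chance of only a limit being reported.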

Compound 3, concentration for total growth inhibition: 54400 nM
Compound 3: middle estimate off by 2.2-fold (0.34 log units), on the high side; low and high end bracket the measured number.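

In this assay, methoxy in place of hydrogen on an aromatic carbon, ortho to a large group and meta to a large group, gives a 1.7-fold lower number from compound 1 to compound 3 (0.23 log units; within the scatter), so adding this group here brings no change beyond the scatter. Compound 3 still returns a number. Compound 2, by contrast, gives a limit and not a number: the limit of > 100000 nM in this assay, at which 1 of the 3 values shown sits.

From the compounds shown here alone, whether an amine, a carboxylic acid or a longer chain such as ethoxy on this aromatic carbon would shift growth inhibition beyond the scatter remains open. So does whether methoxy would behave alike on another core.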